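The compounds below may be only part of what the source reports. "The series", "measured", "known", "first", "only" and "open" are said of these compounds alone.

Measured compounds in an in vitro functional assay on SH-EP1 cells for agonist activity at Neuronal acetylcholine receptor; alpha4/beta2 (Homo sapiens), read by voltage clamp; a higher number here means a larger maximal response, a lower number a smaller maximal response:
compound 1 `C1=C(c2cccnc2)C[C@H]2CNC[C@@H]1C2`: 40%
compound 2 `C1=C(c2cncc(Oc3ccccc3)c2)CC2CNCC1C2`: 9%
compound 3 `CC(C)Oc1cncc(C2=CC3CNCC(C2)C3)c1`: 11%
Not yet measured: compound 4 `CC(C)Oc1cncc(C2=CC3CC(C2)CN(C)C3)c1`

Compound 3 stands second highest of the three numbers. Within the data shown here, its nearest neighbour is compound 2; the single measured step in this set, a number 2 percentage points higher from compound 2 to compound 3 (within the scatter), lies within the scatter, so the two values carry no order. The gap from compound 3 to compound 1 is beyond the scatter, with compound 1 the higher of the two.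

Compound 4 differs from compound 3 by methyl in place of hydrogen on an amine nitrogen in a ring. Among the measured compounds shown here, no measured step bears on this change: the one step known concerns the group on the oxygen on the aromatic ring and says nothing about the amine nitrogen in a ring. For the measured compounds named here, with no comparable step to draw on, in this assay a step of about the scatter is expected, if anything toward the lower side. Compound 4 is therefore estimated at 8% with a range of 2% to 18%. This amounts to an expected step of a number 3 percentage points lower from compound 3 to compound 4 (within the scatter).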

Compound 4, largest response reached (reported as percent of maximum), in percent of the reference or control that the assay uses: 10%
The estimate for compound 4 lay 2 percentage points below the measured number; the measured number falls inside the stated range.
By their numbers in this assay, from the lowest: compounds 2, 4 and 3 (each within the scatter of the next); then compound 1.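

In this assay the amine nitrogen in a ring now has a measured step of its own: methyl in place of hydrogen gives a number 1 percentage points lower from compound 3 to compound 4 (within the scatter), so the two values carry no order. The earlier step concerned only the group on the oxygen on the aromatic ring, whereas this one shows that, with isopropyl on that oxygen, the maximal response does not separate methyl from hydrogen on the nitrogen. No supporting data bear on the reason for this result.

Going by these compounds, whether methyl on the same nitrogen would behave alike in compound 1, which reaches 40% without a group on the oxygen, remains open. Also open, on these data alone, is how a larger group on that nitrogen, such as ethyl or benzyl, would read in this assay.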